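A few compounds are considered here, and "the series" means these few. Any claim that something is new, unique, unknown or untested is made for them only; others in the source may bear on it.

Compound 1 `CCCN(CCC)c1cnc(-c2c(C)cc(C)cc2OC)nc1C` gives the higher of the two values recorded so far: in an in vitro assay on IMR-32 cells for displacement of a labelled ligand from corticotropin-releasing factor receptor 1 (Homo sapiens) (on this read-out lower numbers stand for stronger inhibition and higher numbers for weaker inhibition), compound 1 gives 561 nM. Within the data shown here, the only other measured member of the series, compound 2 `CCCN(CCC)c1c(C)nc(-c2c(OC)cc(C(F)(F)F)cc2C(F)(F)F)nc1OC`, carries a different aryl substitution pattern as well as a methoxy group on the core, and in this assay compound 2 gives 6 nM, which sets it far apart from compound 1. Compound 3 `CCCN(CCC)c1c(C)nc(-c2c(C)cc(C)cc2OC)nc1OC(C)C` keeps the aryl group of compound 1 and changes the core at one point only: isopropoxy in place of hydrogen on an aromatic carbon. Among the measured compounds shown here, no single-point step of this kind has yet been measured, so the comparison rests on the two values alone. Because compound 2 reaches 6 nM with an alkoxy group on the same carbon, a move in the direction of stronger binding is expected for compound 3, though smaller than the whole gap, giving an estimated step of a 4.7-fold lower number from compound 1 to compound 3 (0.67 log units; beyond the scatter). Compound 3 is therefore expected to give about 120 nM, within a range from 30 nM to 500 nM.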

Compound 3, inhibition constant: > 5000 nM
Compound 3 was reported as a limit; the forecaster's own chance of this, stated with the estimate: 2%; middle value at least 41-fold (1.61 log units) away from the limit.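

Among these compounds, on this carbon, next to the ring nitrogen and ortho to a dipropylamino group, isopropoxy in place of hydrogen gives an at least 8.9-fold higher number from compound 1 to compound 3 (0.95 log units; beyond the scatter), the first single-point step, and it runs towards weaker inhibition. The value of compound 3 is a limit of the assay and not a number, so the step gives only a lower bound on the loss: the limit of > 5000 nM in this assay, at which 1 of the 3 values shown sits. With the aryl group of compound 1, then, this position does not take isopropoxy without loss, and compound 2 cannot be read across, as it differs from compound 3 in more than one place.

On these data alone, whether methoxy, ethoxy or an amine on this carbon would keep binding with this aryl group remains open. So does the effect of isopropoxy here alongside the aryl group of compound 2.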